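Methoxy for Chloro on a Shared Core in Mice

The compounds below may be only part of what the source reports. "The series", "measured", "known", "first", "only" and "open" are said of these compounds alone.

Of the compounds shown here, three built on one shared core have been measured in a functional assay on the whole organism with Mus musculus as the target; a higher number here means that more compound is needed for the effect, a lower number that less compound is needed. Compound 1 `O=c1oc2cccnc2n1CCN1CCN(c2ccccc2)CC1` gives 19.4 mg/kg in this assay. Compound 2 `O=c1oc2cccnc2n1CN1CCN(c2ccccc2Cl)CC1` gives 22.2 mg/kg in this assay. Compound 3 `O=c1oc2cccnc2n1CCCN1CCN(c2cccc(C(F)(F)F)c2)CC1` gives 22 mg/kg in this assay. Compound 2 has the highest of the three numbers, but its gap to compound 3 and its gap to compound 1 both lie within the scatter of repeated measurements, so no order among the three can be read from these numbers.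

Compound 4 `COc1ccccc1N1CCN(Cn2c(=O)oc3cccnc32)CC1` has not yet been measured in this assay. It differs from compound 2 in one place: methoxy in place of chloro on an aromatic carbon. For the measured compounds named here, no pair of measured compounds differing only in this way has been recorded, so nothing within these data shows how this exchange shifts the number. The three measured compounds, which differ from one another in more than one place, all sit close together, and on that basis no step beyond the scatter is expected in this assay from this change, in either direction. Compound 4 is therefore estimated at 22 mg/kg, with a range from 11 mg/kg to 44 mg/kg. The step expected a 1.0-fold lower number from compound 2 to compound 4 (0.00 log units; within the scatter) stays within the scatter.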

Compound 4, dose for half-maximal effect: > 25 mg/kg
Compound 4: a limit, no number; the forecaster's own chance of this, stated with the estimate: 5%; middle value at least 1.1-fold (0.05 log units) from the limit.
By their numbers in this assay, from the lowest: compounds 1, 3 and 2 (each within the scatter of the next). At a limit, above all of these: compound 4.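

For the compounds shown here, compounds 2 and 4 form the first pair here that differs in one place, and methoxy in place of chloro on an aromatic carbon, ortho to a large group, gives an at least 1.1-fold higher number from compound 2 to compound 4 (0.05 log units; that floor lies within the scatter) in this assay. The result for compound 4 is a limit and not a number: the limit of > 25 mg/kg in this assay, at which 1 of the 4 values shown sits. Going by these compounds alone, for this one pair, the change from 2-chlorophenyl to 2-methoxyphenyl therefore shows no sign of lowering the number, something the earlier compounds, which differ from one another in more than one place, could not show, yet the floor of the step is too small to establish a rise beyond the scatter.

The compounds shown leave open how far the number of compound 4 lies past its limit, and so whether this exchange has any real effect in the whole animal or leaves the number where it was. They also leave open whether the same exchange behaves alike with the longer chains of compound 1 and compound 3, and how an amine or a carboxylic acid would fare in the same place on the ring.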